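The source may hold more compounds than are shown below. What is called first, only, known or untested is meant among the compounds shown, and "the series" means these compounds.

Measured so far:
compound 1 `CCc1nc2sccn2c1/C=N/OCc1ccc(Cl)c(Cl)c1`: 2600 nM
compound 2 `Clc1cccc(-c2nc3sccn3c2/C=N/OCc2ccc(Cl)c(Cl)c2)c1`: 1100 nM
compound 3 `Clc1ccc(CO/N=C/c2c(-c3ccccc3)nc3sccn23)cc1Cl`: 580 nM

All three were tested in an assay on HepG2 cells for agonist activity at nuclear receptor subfamily 1 group I member 3 (Homo sapiens), read by a luciferase reporter, with a stated time of 23 h; on this read-out lower numbers stand for an effect already at smaller amounts and higher numbers for an effect only at larger amounts of compound. Compound 3 has the lowest number of the three. Its nearest neighbour is compound 2, and the step of a 1.9-fold lower number from compound 2 to compound 3 (0.28 log units; within the scatter) lies within the scatter, so the two cannot be ordered. The step of a 4.5-fold lower number from compound 1 to compound 3 (0.65 log units; beyond the scatter) is beyond the scatter, as is a 2.4-fold lower number from compound 1 to compound 2 (0.37 log units; beyond the scatter); both replace an ethyl group by an aromatic ring on the shared core.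

Compound 4 `FC(F)(F)c1ccc(-c2nc3sccn3c2/C=N/OCc2ccc(Cl)c(Cl)c2)cc1` has not yet been measured. It differs from compound 3 in one place: trifluoromethyl in place of hydrogen on an aromatic carbon. Among the measured compounds shown here, the only measured step that changes a substituent on that phenyl ring is a 1.9-fold lower number from compound 2 to compound 3 (0.28 log units; within the scatter), which stayed within the scatter; the two larger steps concern the swap of ethyl for an aromatic ring and bear on compound 4 only indirectly. A step of a 1.2-fold higher number from compound 3 to compound 4 (0.08 log units; within the scatter) is therefore expected for compound 4, not beyond the scatter, because a 1.9-fold lower number from compound 2 to compound 3 (0.28 log units; within the scatter) showed no real effect of a substituent on this ring. The estimate for compound 4 in this assay is 700 nM, with a range from 250 nM to 2000 nM.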

Compound 4, half-maximal effective concentration: 880 nM
Estimate against measurement, compound 4: 1.3-fold (0.10 log units) below; low and high end bracket the measured number.
By their numbers in this assay, from the lowest: compounds 3, 4 and 2 (each within the scatter of the next); then compound 1.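

Putting trifluoromethyl on the phenyl ring, para to a large group, is tolerated in this assay: the change gives a 1.5-fold higher number from compound 3 to compound 4 (0.18 log units; within the scatter), so four heavy atoms in place of a hydrogen do not measurably shift the number. The two substituted rings cannot be told apart either, with a 1.3-fold lower number from compound 2 to compound 4 (0.10 log units; within the scatter), while a 3.0-fold lower number from compound 1 to compound 4 (0.47 log units; beyond the scatter) shows that the advantage of an aromatic ring over ethyl survives this new substituent. Nothing available explains why this position responds so little.

The only substituents shown on this ring are chloro and trifluoromethyl, so it remains open whether an amine or a carboxylic acid at this place would also leave the number unchanged. Going by these compounds, whether a longer chain in place of the ring could match it also remains open.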